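Methylsulfanyl in place of methoxy in a growth inhibition series

The compounds below may be only part of what the source reports. "The series", "measured", "known", "first", "only" and "open" are said of these compounds alone.

In a functional assay on NCI-H520 cells (Homo sapiens) for cytotoxicity (on this read-out higher numbers stand for weaker inhibition of growth and lower numbers for stronger inhibition of growth), compound 1 (`COc1ccc(C2=C(c3ccc(SC)cc3)CC3CCCN3C2=O)cc1Br`) gives 700 nM and compound 2 (`COc1ccc(C2=C(c3ccc(SC)cc3)CC3CCCN3C2=O)cc1`) gives 800 nM. Among the measured compounds shown here, these two values lie within the scatter of each other, so compound 2 cannot be separated from compound 1, the only other measured compound. Compound 3 (`CSc1ccc(C2=C(c3ccc(SC)cc3)C(=O)N3CCCC3C2)cc1`) differs from compound 2 in one place: methylsulfanyl in place of methoxy on an aromatic carbon. In words, methylsulfanyl stands in place of methoxy on an aromatic carbon, para to a large group, which turns 4-methoxyphenyl into 4-(methylsulfanyl)phenyl.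

For the measured compounds named here, only one measured step is available as a guide, and it bears on this change only indirectly: a 1.1-fold higher number from compound 1 to compound 2 (0.06 log units; within the scatter), with hydrogen in place of bromo on an aromatic carbon. Going by the values given here, that step concerns a different group, and no measured pair exchanges methoxy for methylsulfanyl. No step beyond the scatter is therefore expected in this assay, although two values cannot rule one out. The expected change is a 1.1-fold higher number from compound 2 to compound 3 (0.05 log units; within the scatter). For compound 3 the estimated value is 900 nM, with an expected range from 300 nM to 3000 nM.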

Compound 3, concentration for 50% growth inhibition: 15000 nM
Estimate against measurement, compound 3: 17-fold (1.22 log units) below; measured number above the stated range.
By their numbers in this assay, from the lowest: compounds 1 and 2 (each within the scatter of the next); then compound 3.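

In this assay the group on this aromatic carbon, para to a large group, proves decisive: the exchange of methoxy for methylsulfanyl gives a 19-fold higher number from compound 2 to compound 3 (1.27 log units; beyond the scatter) and so weakens growth inhibition well beyond the scatter. The earlier step on the same ring, the removal of bromo, gave only a 1.1-fold higher number from compound 1 to compound 2 (0.06 log units; within the scatter) and lay within the scatter, so the shared core does not tolerate every change on this ring equally, and the result for the methoxy position could not have been read from that step. The change from 3-bromo-4-methoxyphenyl to 4-(methylsulfanyl)phenyl gives a 21-fold higher number from compound 1 to compound 3 (1.33 log units; beyond the scatter) and is also large, while no measurement available here accounts for the weaker growth inhibition of compound 3.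

The compounds shown leave open whether a hydroxy, an ethoxy, a chloro or a dimethylamino group at this place would stay close to compound 2 or fall towards compound 3. They also leave open how the methylsulfanyl on the other aromatic ring, which all three compounds carry, would behave if a methoxy stood there instead.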